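The compounds below may be only part of what the source reports. "The series", "measured", "known", "first", "only" and "open" are said of these compounds alone.

Of the compounds shown here, two sharing the same core have been tested in a functional assay (muscle tissue) with Cavia porcellus as the target; a higher number here means that more compound is needed for the effect, a lower number that less compound is needed. Compound 1, `COC(=O)C1=C(C)N=C(C)/C(=C(\O)OC)C1c1ccccc1N`, gives 39800 nM in this assay. Compound 2, `COC(=O)C1=C(C)N=C(C)/C(=C(\O)OC)C1c1ccc(I)cc1`, gives 22900 nM in this assay. Within the data shown here, the single measured step, a 1.7-fold lower number from compound 1 to compound 2 (0.24 log units; within the scatter), puts 4-iodophenyl in place of 2-aminophenyl on a saturated ring carbon, and since it stays within the scatter, compound 2 and compound 1 cannot be told apart on these numbers. Compound 3, `COC(=O)C1=C(C)N=C(C)/C(=C(\O)OC)C1c1ccc(Br)cc1`, differs from compound 2 in one place: bromo in place of iodo on an aromatic carbon. Among the measured compounds shown here, no measured step exchanges one halogen for another, so the only guide is that a much larger exchange at the same position produced nothing beyond the scatter. The step of a 1.1-fold higher number from compound 2 to compound 3 (0.04 log units; within the scatter) is therefore expected to stay within the scatter. Compound 3 is estimated at 25000 nM in this assay, with a likely range from 10000 nM to 60000 nM.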

Compound 3, half-maximal effective concentration: 540 nM
Beside the measured number, compound 3's estimate is 46-fold (1.67 log units) above it; the measured number lies below the stated range.
By their numbers in this assay, from the lowest: compound 3; then compounds 2 and 1 (each within the scatter of the next).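

In this assay the halogen on the aromatic carbon turns out to matter a great deal: a 42-fold lower number from compound 2 to compound 3 (1.63 log units; beyond the scatter) is a large step, even though bromo and iodo each count as one heavy atom with no hydrogen-bond donors or acceptors. Among these compounds, the first pair of compounds gave no sign of this sensitivity, whereas a 74-fold lower number from compound 1 to compound 3 (1.87 log units; beyond the scatter) shows that exchanging 2-aminophenyl on the saturated ring carbon can shift the number far beyond the scatter when the new group is 4-bromophenyl. No evidence at hand explains why swapping one halogen for another has so large an effect. Still open, going by these compounds, is whether the low number belongs to bromo alone or would also appear with chloro, fluoro or a methyl group on the same aromatic carbon. Also open, on these data alone, is whether bromo would give a similar number on another carbon of that ring.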